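This account rests on a few compounds, and the source may have more. Where it says the series, first, only, none or still open, it means among the compounds named here.

Of the compounds shown here, three have been tested in a physicochemical assay for solubility; on this read-out lower numbers stand for lower solubility and higher numbers for higher solubility. Compound 1 `O=C(Nc1ccc(F)cc1Cl)c1cc(Cl)ccc1O` carries a single chloro group on the anilide ring, and in this assay compound 1 gives 1.2 ug/mL. Compound 2 `O=C(Nc1c(Cl)cc(F)cc1Cl)c1cc(Cl)ccc1O` adds a second one; the change is chloro in place of hydrogen on an aromatic carbon. In this assay compound 2 gives > 49 ug/mL, and this figure is a limit of the assay rather than a number. The step is an at least 40-fold higher number from compound 1 to compound 2 (1.61 log units; beyond the scatter), with compound 2 resting at the limit of > 49 ug/mL in this assay, at which 1 of the 3 values shown sits.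

Compound 3 `COc1cccc(NC(=O)c2cc(Cl)ccc2O)c1` carries a methoxy group instead, and in this assay compound 3 gives 2.3 ug/mL. The difference between its core and that of compound 1 is not broken down here, and its value sits within the scatter of compound 1.

Compound 4 `COc1ccc(Cl)c(NC(=O)c2cc(Cl)ccc2O)c1` has not yet been measured. Going by the values given here, it differs from compound 3 by chloro in place of hydrogen on an aromatic carbon, which is the same kind of change as the one from compound 1 to compound 2, although the surroundings differ: in compound 4 the entering chloro group is para to a methoxy group, whereas in compound 2 it is meta to a chloro group and meta to a fluoro group. Among the compounds with values here, because the step of an at least 40-fold higher number from compound 1 to compound 2 (1.61 log units; beyond the scatter) was large, some rise is expected, yet compound 4 ends up with only one chloro group on that ring, as compound 1 does, so a smaller step of a 1.7-fold higher number from compound 3 to compound 4 (0.24 log units; within the scatter) is estimated. Compound 4 is expected to give about 4 ug/mL, roughly between 1.2 ug/mL and 20 ug/mL.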

Compound 4, solubility: < 1 ug/mL
Compound 4: only a limit was reported; the forecaster's own chance of this, stated with the estimate: 12%; at least 4.0-fold (0.60 log units) between middle value and limit.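

The same change, chloro in place of hydrogen on an aromatic carbon, pointed in opposite directions on the two cores: in this assay the earlier step is an at least 40-fold higher number from compound 1 to compound 2 (1.61 log units; beyond the scatter), while the new step is an at least 2.3-fold lower number from compound 3 to compound 4 (0.36 log units; beyond the scatter). From the compounds shown here alone, compound 4 gives < 1 ug/mL, which is a limit of the assay and not a number, so the full size of the new step remains unknown. Two steps cannot set a rule, but they do show that the direction of this change did not carry over from one core to the other; they do not show what decides that direction, whether the place of the entering chloro group, para to a methoxy group in compound 4, or some other part of the core.

The compounds shown leave open whether a chloro group placed elsewhere on the ring of compound 3 would follow compound 2 or compound 4. They also leave open how an amine or a carboxylic acid in place of the chloro group of compound 4 would read in this assay, which would show whether the outcome at that place is tied to chloro itself.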